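The source may hold more compounds than are shown below. What is called first, only, known or untested is meant among the compounds shown, and "the series" means these compounds.

Compound 2 `c1c[nH]c(-c2ccccc2OCC2=NCCN2)c1` gives 99% in a functional assay with Alpha-1A adrenergic receptor (Homo sapiens) as the target, read by calcium flux (a higher number here means a larger maximal response, a lower number a smaller maximal response), the second highest of three numbers: compound 1 `c1coc(-c2ccccc2OCC2=NCCN2)c1` gives 106% and compound 3 `Cc1ccc(-c2ccccc2OCC2=NCCN2)s1` gives 97%, both within the scatter of compound 2. Compound 4 `Cn1nccc1-c1ccccc1OCC1=NCCN1` differs from compound 2 by 1-methyl-1H-pyrazol-5-yl in place of 1H-pyrrol-2-yl on an aromatic carbon. Among the compounds with values here, two measured steps bear on this change, each a swap of the five-membered aromatic ring on the same aromatic carbon: a number 7 percentage points lower from compound 1 to compound 2 (within the scatter) and a number 2 percentage points lower from compound 2 to compound 3 (within the scatter). Neither moved the maximal response beyond the scatter, so for compound 4 no change beyond the scatter is expected in this assay, the expected step being a number 2 percentage points lower from compound 2 to compound 4 (within the scatter). Compound 4 is therefore estimated to give 97% in this assay, with a range from 85% to 110%.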

Compound 4, largest response reached (reported as maximum), in percent of the reference or control that the assay uses: 107%
Estimate against measurement, compound 4: 10 percentage points below, within the range that was stated.
By their numbers in this assay, from the lowest: compounds 3, 2, 1 and 4 (each within the scatter of the next).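

In this assay, 1-methyl-1H-pyrazol-5-yl on this aromatic carbon stays within the scatter of all three earlier groups: a number 8 percentage points higher from compound 2 to compound 4 (within the scatter), a number 10 percentage points higher from compound 3 to compound 4 (within the scatter) and a number 1 percentage points higher from compound 1 to compound 4 (within the scatter). Within the data shown here, the maximal response at this position therefore also holds for a five-membered aromatic ring with 2 hetero atoms, a ring type absent from the earlier compounds. No evidence is available on the cause of this result. All four groups are five-membered aromatic rings, so the compounds shown leave open how a pyridine ring, an amine or a carboxylic acid would behave at this position.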